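Working notes: the step to a plain 4-hydroxyphenyl

The compounds below may be only part of what the source reports. "The series", "measured", "known", "first", "only" and "open" are said of these compounds alone.

Of the compounds shown here, three sharing one core have been measured so far, and they differ only in the aryl group on the carbon with a double bond to nitrogen. In a functional assay on A549 cells (Homo sapiens) for cytotoxicity, read by MTT assay, with a stated time of 72 h (a higher number here means a weaker inhibitor, a lower number a stronger inhibitor), compound 1 `COc1cc2ncnc(Nc3ccc(F)c(Cl)c3)c2cc1NC(=O)N/N=C/c1ccc(F)cc1` gives 26600 nM, compound 2 `COc1ccc(/C=N/NC(=O)Nc2cc3c(Nc4ccc(F)c(Cl)c4)ncnc3cc2OC)cc1` gives 28100 nM and compound 3 `COc1cc2ncnc(Nc3ccc(F)c(Cl)c3)c2cc1NC(=O)N/N=C/c1cc(Br)c(O)c(Br)c1` gives 34600 nM. Compound 3 therefore stands level with the other two, as the measured steps show: a 1.3-fold higher number from compound 1 to compound 3 (0.11 log units; within the scatter) and a 1.2-fold higher number from compound 2 to compound 3 (0.09 log units; within the scatter).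

The next structure is compound 4 `COc1cc2ncnc(Nc3ccc(F)c(Cl)c3)c2cc1NC(=O)N/N=C/c1ccc(O)cc1`, with 4-hydroxyphenyl in place of 3,5-dibromo-4-hydroxyphenyl on a carbon with a double bond to nitrogen. Going by the values given here, this exact exchange has not been measured, and no measured compound carries the 4-hydroxyphenyl group. The closest evidence is the set of exchanges at the same place, namely the two steps above and a 1.1-fold higher number from compound 1 to compound 2 (0.02 log units; within the scatter). All three stayed within the scatter, so no shift beyond the scatter is expected in this assay, and no direction is favoured with any confidence. The expected change is a 1.2-fold lower number from compound 3 to compound 4 (0.08 log units; within the scatter). For compound 4 the estimated value is 29000 nM, with an expected range from 15000 nM to 55000 nM.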

Compound 4, half-maximal inhibitory concentration: 7610 nM
The estimate for compound 4 lay 3.8-fold (0.58 log units) above the measured number, outside the stated range (below it).
By their numbers in this assay, from the lowest: compound 4; then compounds 1, 2 and 3 (each within the scatter of the next).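

In this assay this position is no longer silent: the aryl group on the carbon with a double bond to nitrogen can move the number beyond the scatter, as shown by a 4.5-fold lower number from compound 3 to compound 4 (0.66 log units; beyond the scatter) on the loss of both bromines. The plain 4-hydroxyphenyl group also sets compound 4 apart from the two groups without a hydroxy, with a 3.7-fold lower number from compound 2 to compound 4 (0.57 log units; beyond the scatter) for hydrogen in place of methyl on the oxygen and a 3.5-fold lower number from compound 1 to compound 4 (0.54 log units; beyond the scatter) for hydroxy in place of fluoro, yet compound 3 goes against any rule based on the hydroxy alone, since it carries one and still stands level with compound 1 and compound 2. No measurement at hand accounts for this behaviour of the 4-hydroxyphenyl group.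

From the compounds shown here alone, it remains open whether the lower number depends on the hydroxy at all, or would also appear with an amine or a carboxylic acid in its place on the phenyl ring. Going by these compounds, it is equally open whether a phenyl ring with a single bromine would sit with compound 3 or with compound 4.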